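Pyrazole amides: methyl to trifluoromethyl on the core

A few compounds are considered here, and "the series" means these few. Any claim that something is new, unique, unknown or untested is made for them only; others in the source may bear on it.

Measured so far in a functional assay on cells for antagonist activity at C-C chemokine receptor type 1 (Homo sapiens), read by FLIPR and calcium flux; on this read-out higher numbers stand for weaker inhibition and lower numbers for stronger inhibition:
compound 1, `Cc1c(C(=O)NCc2cccc(C(F)(F)F)c2)cnn1-c1ccc(Cl)c(Cl)c1`, 500 nM
compound 2, `Cc1c(C(=O)NCc2cccc(C(F)(F)F)c2)cnn1-c1ccc(Cl)cc1`, 600 nM
compound 3, `Cc1c(C(=O)NCc2cccc(C(F)(F)F)c2)cnn1Cc1ccccc1`, > 3000 nM

Compound 2 and compound 1 lie within the scatter of each other, as the step of a 1.2-fold higher number from compound 1 to compound 2 (0.08 log units; within the scatter) shows. Compound 3 is recorded only as a limit of this assay (the limit of > 3000 nM in this assay, at which 1 of the 3 values shown sits). The step of an at least 5.0-fold higher number from compound 2 to compound 3 (0.69 log units; beyond the scatter) and the step of an at least 6.0-fold higher number from compound 1 to compound 3 (0.77 log units; beyond the scatter) both fall beyond the scatter, but each concerns the group on the ring nitrogen, not the methyl on the core.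

Compound 4, `O=C(NCc1cccc(C(F)(F)F)c1)c1cnn(-c2ccc(Cl)cc2)c1C(F)(F)F`, differs from compound 2 by trifluoromethyl in place of methyl on an aromatic carbon. Among the measured compounds shown here, no measured step touches this position: the methyl is kept unchanged across compound 1, compound 2 and compound 3, so the data give no direction for the step. The expectation in this assay is therefore a step of no change at the digits printed from compound 2 to compound 4 (within the scatter) that stays within the scatter. On these data alone, compound 4 is estimated at 600 nM, with a range from 200 nM to 2000 nM, the range being wide since the change is untested.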

Compound 4, half-maximal inhibitory concentration: > 3000 nM
Compound 4 gave a limit, no number; the forecaster's own chance of this, stated with the estimate: 15%; middle value at least 5.0-fold (0.69 log units) away from the limit.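

In this assay, among the compounds shown here, only this pair varies the methyl on the core, and the change is not neutral: an at least 5.0-fold higher number from compound 2 to compound 4 (0.69 log units; beyond the scatter). Compound 4 gives > 3000 nM, a limit of the assay and not a number. Compound 4 now stands with compound 3 at that limit, reached here through a change on the core and not through the group on the ring nitrogen, so this position counts in the series as much as the ring nitrogen does: the limit of > 3000 nM in this assay, at which 2 of the 4 values shown sit.

On these data alone, whether hydrogen, ethyl or a nitrile at this position would keep the level of compound 2 stays open. As far as these compounds go, whether the step from methyl to trifluoromethyl carries over to the 3,4-dichlorophenyl group of compound 1 stays open as well.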